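This account rests on a few compounds, and the source may have more. Where it says the series, first, only, none or still open, it means among the compounds named here.

Measured so far:
compound 1 `CCCCN(c1nc2c(NS(C)(=O)=O)cccc2o1)[C@H](C)c1ccc(-c2ccccc2-c2nnn[nH]2)cc1` gives 4.7 h
compound 2 `CCCCN(c1nc2c(C(=O)NC)cccc2o1)[C@H](C)c1ccc(-c2ccccc2-c2nnn[nH]2)cc1` gives 1.3 h
compound 3 `CCCCN(c1nc2c(CO)cccc2o1)[C@H](C)c1ccc(-c2ccccc2-c2nnn[nH]2)cc1` gives 1.6 h

In an ADME assay on the whole organism (Macaca fascicularis) for metabolic stability, read by LC-MS, using cassette dosing, at a dose of 1 mg/kg by the oral route (a higher number here means that the compound lasts longer, a lower number that the compound disappears faster), compound 3 stands second highest of the three numbers. Its nearest neighbour is compound 2, and the step of a 1.2-fold higher number from compound 2 to compound 3 (0.09 log units; within the scatter) lies within the scatter, so the two cannot be told apart. Compound 1 sits clearly higher, as the step of a 2.9-fold lower number from compound 1 to compound 3 (0.47 log units; beyond the scatter) shows.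

Compound 4 `CCCCN(c1nc2c(C(=O)N(C)C)cccc2o1)[C@H](C)c1ccc(-c2ccccc2-c2nnn[nH]2)cc1` has not yet been measured. It differs from compound 3 in one place: dimethylcarbamoyl in place of hydroxymethyl on an aromatic carbon. The step that bears most directly on this change is a 1.2-fold higher number from compound 2 to compound 3 (0.09 log units; within the scatter), since compound 2 carries a methylcarbamoyl group at the same place, and that step was within the scatter. The steps of a 3.6-fold lower number from compound 1 to compound 2 (0.56 log units; beyond the scatter) and a 2.9-fold lower number from compound 1 to compound 3 (0.47 log units; beyond the scatter) also show that the methylcarbamoyl and hydroxymethyl compounds sit a similar distance below compound 1. On this basis no step beyond the scatter is expected, and the estimated step is a 1.1-fold lower number from compound 3 to compound 4 (0.06 log units; within the scatter). Compound 4 is therefore expected to give about 1.4 h, with a likely range from 0.7 h to 2.8 h.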

Compound 4, half-life: 3.2 h
Estimate against measurement, compound 4: 2.3-fold (0.36 log units) below, and the stated range ends below it.
By their numbers in this assay, from the lowest: compounds 2, 3, 4 and 1 (each within the scatter of the next, the first and the last beyond it).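

In this assay, among these compounds, the amide at this place responds to one small change, methyl in place of hydrogen on an amide-type nitrogen, which gives a 2.5-fold higher number from compound 2 to compound 4 (0.39 log units; beyond the scatter) and is the only new step beyond the scatter. Within the scatter lie a 2.0-fold higher number from compound 3 to compound 4 (0.30 log units; within the scatter) and a 1.5-fold lower number from compound 1 to compound 4 (0.17 log units; within the scatter) which means that the dimethylcarbamoyl group cannot be told apart here from hydroxymethyl or from methanesulfonamido. Compound 1 is therefore no longer alone in standing clearly above compound 2, and two amides that differ by a single methyl do not give the same half-life.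

The compounds shown leave open whether a larger amide such as diethylcarbamoyl would go further, and where a carboxylic acid at this place would fall. No measurement here explains why the added methyl matters.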